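Aryl-piperazine variation in the shared core: compound 3 outlook

The source may report more compounds than this note shows. Statements on the series, on what has been measured and on what is new or still open speak of the compounds shown alone.

Compound 2 `CCCc1nc(-c2ccccc2)c(CNCCCN2CCN(c3cccc(F)c3)CC2)o1` gives 3030 nM in an assay on HEK293 cells for inhibition of Voltage-dependent T-type calcium channel subunit alpha-1G (Homo sapiens), read by patch clamp; on this read-out lower numbers stand for stronger inhibition and higher numbers for weaker inhibition; compound 1 `CCCc1nc(-c2ccccc2)c(CNCCCN2CCN(c3ccc(F)cc3)CC2)o1` gives 3210 nM, and the two lie within the scatter of each other, as a 1.1-fold lower number from compound 1 to compound 2 (0.03 log units; within the scatter) shows. Compound 3 `CCCc1nc(-c2ccccc2)c(CNCCCN2CCN(c3ccccc3Cl)CC2)o1` carries 2-chlorophenyl in place of 3-fluorophenyl on an amine nitrogen in a ring. For the measured compounds named here, only the step from compound 1 to compound 2, an exchange of one fluorophenyl for another on the same ring nitrogen, bears on this change, and it stayed within the scatter; no measured step covers chlorine or a 2-substituted phenyl, so the expectation rests on that single step alone. The estimated step is a 1.0-fold lower number from compound 2 to compound 3 (0.00 log units; within the scatter), within the scatter. Compound 3 is therefore expected to give 3000 nM, within a range from 1200 nM to 7500 nM.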

Compound 3, half-maximal inhibitory concentration: 2800 nM
Beside the measured number, compound 3's estimate is 1.1-fold (0.03 log units) above it; the range from low to high includes it.
By their numbers in this assay, from the lowest: compounds 3, 2 and 1 (each within the scatter of the next).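

In this assay the 2-chlorophenyl group on the amine nitrogen in the ring stays within the scatter of both fluorophenyl groups (a 1.1-fold lower number from compound 2 to compound 3 (0.03 log units; within the scatter); a 1.1-fold lower number from compound 1 to compound 3 (0.06 log units; within the scatter)). This position therefore accommodates a change of halogen together with a change of its place on the phenyl, whereas the earlier pair covered only fluorine at two places. Nothing available explains why these values sit together.

As far as these compounds go, whether a methoxy group or a carboxylic acid on the phenyl would keep the number in this range remains open. So does the effect of an unsubstituted phenyl on that nitrogen.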